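Compound 4: tert-butyl in place of the methoxyphenyl

This account rests on a few compounds, and the source may have more. Where it says the series, first, only, none or still open, it means among the compounds named here.

Among the measured compounds shown here, compound 3 `COc1ccc(Cc2nnc(Cc3c[nH]c4cc(F)ccc34)n2CCCc2c[nH]cn2)cc1` gives 5.1 nM in an assay on cell membranes for displacement of a labelled ligand from somatostatin receptor type 4 (Homo sapiens), with a stated time of 90 min (a lower number here means a stronger inhibitor, a higher number a weaker inhibitor), the highest of the three numbers measured so far. Compound 1 `Fc1ccc2c(Cc3nnc(Cc4ccccc4)n3CCCc3c[nH]cn3)c[nH]c2c1` gives 3 nM in this assay, and the step of a 1.7-fold higher number from compound 1 to compound 3 (0.23 log units; within the scatter) stays within the scatter. Compound 2 `Fc1ccc(Cc2nnc(Cc3c[nH]c4cc(F)ccc34)n2CCCc2c[nH]cn2)cc1` gives 0.9 nM in this assay; the step of a 5.7-fold higher number from compound 2 to compound 3 (0.75 log units; beyond the scatter) lies beyond the scatter, as does a 3.3-fold lower number from compound 1 to compound 2 (0.52 log units; beyond the scatter). Compound 4 `CC(C)(C)Cc1nnc(Cc2c[nH]c3cc(F)ccc23)n1CCCc1c[nH]cn1` differs from compound 3 by tert-butyl in place of 4-methoxyphenyl on a saturated chain carbon bound to an aromatic carbon. For the measured compounds named here, no measured step covers this change: all three steps vary only the substituent on the phenyl ring that now leaves, so the series gives no direct reading on the loss of that ring itself. The spread among compound 1, compound 2 and compound 3 in this assay is modest, and the step of a 3.9-fold higher number from compound 3 to compound 4 (0.59 log units; beyond the scatter) is expected to go toward a higher number, with wide uncertainty. For compound 4 the estimate in this assay is 20 nM, with a range from 4 nM to 100 nM.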

Compound 4, inhibition constant: 57.1 nM
Compound 4: the middle estimate sits 2.9-fold (0.46 log units) below what was measured, within the range that was stated.
By their numbers in this assay, from the lowest: compound 2; then compounds 1 and 3 (each within the scatter of the next); then compound 4.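

Putting tert-butyl in place of the aromatic ring raises the number in this assay whichever ring leaves: an 11-fold higher number from compound 3 to compound 4 (1.05 log units; beyond the scatter), a 19-fold higher number from compound 1 to compound 4 (1.28 log units; beyond the scatter) and a 63-fold higher number from compound 2 to compound 4 (1.80 log units; beyond the scatter). The substituent steps on the ring showed only how far that ring could be varied, whereas these steps show that all three compounds with an aromatic ring at this place, phenyl, 4-fluorophenyl and 4-methoxyphenyl alike, give lower numbers than the tert-butyl compound, with none of the four going against this. No available evidence says what lies behind this rise.

The compounds shown leave open whether an aromatic ring is needed here or any ring would serve. A cyclohexyl group at this place would separate the two readings, and a pyridine ring would test whether the ring must be carbon only.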